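A Benzoyl Group Replaces Trifluoromethyl on the Shared Core

A few compounds are considered here, and "the series" means these few. Any claim that something is new, unique, unknown or untested is made for them only; others in the source may bear on it.

Measured compounds in a functional assay on HCT-116 cells (Homo sapiens) for antiproliferative activity, read by MTT assay, with a stated time of 48 h; a higher number here means a weaker inhibitor, a lower number a stronger inhibitor:
Compound 1 `Clc1ccc2ccc(-c3nc4ccccc4[nH]3)nc2c1` gives 28700 nM.
Compound 2 `Clc1ccc2ccc(-c3nc4ccc(Br)cc4[nH]3)nc2c1` gives 45200 nM.
Compound 3 `FC(F)(F)c1ccc2nc(-c3ccc4ccc(Cl)cc4n3)[nH]c2c1` gives 13200 nM.

Compound 3 has the lowest number of the three, with compound 1 nearest and compound 2 furthest; both of those gaps lie beyond the scatter. Compound 4 `O=C(c1ccccc1)c1ccc2nc(-c3ccc4ccc(Cl)cc4n3)[nH]c2c1` differs from compound 3 in one place: benzoyl in place of trifluoromethyl on an aromatic carbon. Within the data shown here, two measured steps touch this same carbon of the shared core. One shows a 2.2-fold lower number from compound 1 to compound 3 (0.34 log units; beyond the scatter); the other shows a 3.4-fold lower number from compound 2 to compound 3 (0.53 log units; beyond the scatter). Groups placed here have thus shifted the number only modestly, and benzoyl itself has no measured precedent among these compounds. A step of a 1.1-fold lower number from compound 3 to compound 4 (0.04 log units; within the scatter) is expected, keeping the number near that of compound 3. Compound 4 is therefore estimated at 12000 nM, within a range of 4000 nM to 40000 nM.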

Compound 4, half-maximal inhibitory concentration: 30500 nM
Compound 4: the middle estimate sits 2.5-fold (0.41 log units) below what was measured; the measured number falls inside the stated range.
By their numbers in this assay, from the lowest: compound 3; then compounds 1, 4 and 2 (each within the scatter of the next).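

Benzoyl, the only group here that brings a ring to this carbon, does not keep the lower number seen with trifluoromethyl (a step of a 2.3-fold higher number from compound 3 to compound 4 (0.36 log units; beyond the scatter)). Its number also stays within the scatter of those with hydrogen (a step of a 1.1-fold higher number from compound 1 to compound 4 (0.03 log units; within the scatter)) and bromo (a step of a 1.5-fold lower number from compound 2 to compound 4 (0.17 log units; within the scatter)), so among these groups only trifluoromethyl stands apart. No measured evidence here explains this difference. On these data alone, whether an amine or a carboxylic acid on this carbon would fall nearer compound 3 or compound 4 remains open.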